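One Added Methyl at the Limit of the Assay

The compounds below may be only part of what the source reports. "The series", "measured", "known", "first", "only" and "open" are said of these compounds alone.

In a functional assay on HepG2 cells (Homo sapiens) for antiproliferative activity, read by sulforhodamine B assay, with a stated time of 72 h (on this read-out higher numbers stand for weaker inhibition and lower numbers for stronger inhibition), two compounds have been tested so far, and neither gave a number. Compound 1 (`C[C@@H](NC(=O)OC(C)(C)C)C(=O)Nc1ccc2ncnc(Nc3ccc(F)c(Cl)c3)c2c1`) reads > 50000 nM, which is a limit of the assay. Compound 2 (`CC(C)(C)OC(=O)NCC(=O)Nc1ccc2ncnc(Nc3cccc(C(F)(F)F)c3)c2c1`) reads > 50000 nM, again a limit. The data thus stand at the limit of > 50000 nM in this assay, at which 2 of the 2 values shown sit, and compound 2 has no more exact position than that.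

Compound 3 (`C[C@@H](NC(=O)OC(C)(C)C)C(=O)Nc1ccc2ncnc(Nc3cccc(C(F)(F)F)c3)c2c1`) differs from compound 2 in one place: methyl in place of hydrogen on a saturated chain carbon bound to an amide-type nitrogen and a carbonyl carbon. This puts methyl in place of hydrogen on a saturated chain carbon bound to an amide-type nitrogen and a carbonyl carbon, turning ((tert-butoxycarbonyl)amino)methyl into 1-((tert-butoxycarbonyl)amino)ethyl. Going by the values given here, no measured step shows what this change does in this assay. The closest guide is compound 1, which already carries 1-((tert-butoxycarbonyl)amino)ethyl and still reads > 50000 nM, a limit. The expected change is a number no higher from compound 2 to compound 3 (the limit leaves the size open), and it is expected to stay within the usual scatter, with no direction favoured. Compound 3 is estimated at 50000 nM, with an expected range of 25000 nM to 100000 nM.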

Compound 3, half-maximal inhibitory concentration: > 50000 nM
Compound 3: only a limit was reported; the forecaster's own chance of this, stated with the estimate: 85%; the middle value lies on the limit itself.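

Compound 3 reads > 50000 nM, which is a limit of the assay. The steps from compound 1 and from compound 2 to compound 3 therefore cannot be read in this assay, and the series stands at a single mark: the limit of > 50000 nM in this assay, at which 3 of the 3 values shown sit.

The compounds shown leave open whether the added methyl or the 3-(trifluoromethyl)phenyl group has any effect on the read-out, as none of the three has a number.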